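The source may hold more compounds than are shown below. What is called first, only, known or untested is meant among the compounds shown, and "the series" means these compounds.

Measured so far:
compound 1, `CCOc1nc2c(c(=O)n(C)c(=O)n2C)n1CCCC(=O)Nc1ccc(C(C)C)cc1`, 96300 nM in an assay on isolated protein for inhibition of high affinity 3',5'-cyclic-AMP phosphodiesterase 7A (Homo sapiens), read by cAMP accumulation, with a stated time of 10 min; on this read-out lower numbers stand for stronger inhibition and higher numbers for weaker inhibition
compound 2, `CCCOc1nc2c(c(=O)n(C)c(=O)n2C)n1CCCC(=O)Nc1ccc(C(C)(C)C)cc1`, 7760 nM in this assay

Of these two numbers, compound 2 holds the lower one, and the gap to compound 1 lies beyond the usual scatter. Compound 3, `CCCOc1nc2c(c(=O)n(C)c(=O)n2C)n1CCCC(=O)Nc1ccc(C(C)C)cc1`, has not yet been measured. It differs from compound 2 by hydrogen in place of methyl on a saturated chain carbon bound to an aromatic carbon and two saturated chain carbons, so the changed ring substituent of compound 3 matches that of compound 1. No single change between measured compounds is available to guide the size of this step. An increase in the number is expected, estimated as a 2.6-fold higher number from compound 2 to compound 3 (0.41 log units; beyond the scatter). Compound 3 is therefore expected to give about 20000 nM in this assay, within a range of 8000 nM to 60000 nM.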

Compound 3, half-maximal inhibitory concentration: 37600 nM
Estimate against measurement, compound 3: 1.9-fold (0.27 log units) below; low and high end bracket the measured number.
By their numbers in this assay, from the lowest: compound 2; then compound 3; then compound 1.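

Taking one methyl off the tert-butyl group to leave isopropyl weakens inhibition in this assay, giving a 4.8-fold higher number from compound 2 to compound 3 (0.69 log units; beyond the scatter) on this change alone. Methyl in place of hydrogen on a saturated chain carbon, two bonds along the chain from an oxygen on an aromatic ring, moves the number the other way, giving a 2.6-fold lower number from compound 1 to compound 3 (0.41 log units; beyond the scatter) as a separate step. No measurement shown explains either step. Going by these compounds, whether a longer chain on that oxygen, such as butoxy, or a trifluoromethyl group in place of tert-butyl would strengthen inhibition further remains open.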